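Replacing the carbamate on the ring nitrogen of compound 2

The compounds below may be only part of what the source reports. "The series", "measured", "known", "first", "only" and "open" are said of these compounds alone.

Compound 1 `C[C@H](CF)OC(=O)N1CCC(O[C@H]2CC[C@H](Oc3cnc(S(C)(=O)=O)cn3)CC2)CC1` gives 317 nM in a functional assay on isolated protein for agonist activity at Glucose-dependent insulinotropic receptor (Rattus norvegicus), read by HTRF and cAMP accumulation; on this read-out higher numbers stand for an effect only at larger amounts of compound and lower numbers for an effect already at smaller amounts.
Compound 2 `CS(=O)(=O)c1cnc(O[C@H]2CC[C@H](OC3CCN(C(=O)OC4CCOC4)CC3)CC2)cn1` gives 1500 nM in this assay.

Compound 2 stands highest of the two numbers; its nearest neighbour is compound 1, separated by a 4.7-fold higher number from compound 1 to compound 2 (0.68 log units; beyond the scatter). Compound 3 `CS(=O)(=O)c1cnc(O[C@H]2CC[C@H](OC3CCN(CC4(C(F)(F)F)CC4)CC3)CC2)cn1` differs from compound 2 by (1-(trifluoromethyl)cyclopropyl)methyl in place of ((oxolan-3-yl)oxy)carbonyl on an amine nitrogen in a ring. Within the data shown here, the single measured step, a 4.7-fold higher number from compound 1 to compound 2 (0.68 log units; beyond the scatter), exchanged only the group on the oxygen next to the carbonyl and does not bear on removing the whole carbamate, so no measured step covers this change. Compound 3 is therefore expected to lie near compound 2, a step of no change at the digits printed from compound 2 to compound 3 (within the scatter), with an estimate of 1500 nM and a wide range from 300 nM to 8000 nM.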

Compound 3, half-maximal effective concentration: 163 nM
For compound 3 the middle estimate is 9.2-fold (0.96 log units) above the measured one; the measured number lies below the stated range.
By their numbers in this assay, from the lowest: compounds 3 and 1 (each within the scatter of the next); then compound 2.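

In this assay, the carbonyl of the carbamate on the amine nitrogen in a ring is not needed: with (1-(trifluoromethyl)cyclopropyl)methyl in place of ((oxolan-3-yl)oxy)carbonyl, there is a 9.2-fold lower number from compound 2 to compound 3 (0.96 log units; beyond the scatter). The same group also holds its own against the carbamate of compound 1, with a 1.9-fold lower number from compound 1 to compound 3 (0.29 log units; within the scatter), so the two cannot be ordered. Nothing shown here accounts for the change. Still open, going by these compounds, is how much the trifluoromethyl and the cyclopropane each contribute, and whether a plain cyclopropylmethyl, an amide or a urea on this nitrogen would read similarly.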